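A ring change on a poorly absorbed compound

A few compounds are considered here, and "the series" means these few. Any claim that something is new, unique, unknown or untested is made for them only; others in the source may bear on it.

In an ADME assay on the whole organism (strain Sprague-Dawley) for pharmacokinetics, with Rattus norvegicus as the target, at a dose of 5 mg/kg by the oral route (a lower number here means that a smaller share of the oral dose reaches the circulation, a higher number that a larger share of the oral dose reaches the circulation), compound 1 `COc1c(/C=C/c2ccc(NS(C)(=O)=O)c(F)c2)cc(-n2ccc(=O)[nH]c2=O)cc1C(C)(C)C` gives 76% and compound 2 `COc1c(/C=C/c2ccc(NS(C)(=O)=O)cc2)cc(N2CCC(=O)NC2=O)cc1C(C)(C)C` gives 18% as the lower of the two numbers, with a gap beyond the usual scatter. Compound 3 `COc1c(/C=C/c2ccc(NS(C)(=O)=O)cc2)cc(-n2ccc(=O)[nH]c2=O)cc1C(C)(C)C` departs from compound 2 through one change a group of 8 heavy atoms (4 carbon, 2 nitrogen, 2 oxygen; one six-membered aromatic ring with 2 hetero atoms) in place of a group of 8 heavy atoms (4 carbon, 2 nitrogen, 2 oxygen; one six-membered non-aromatic ring with 2 hetero atoms), on an aromatic carbon on an aromatic carbon. Among the measured compounds shown here, no measured step isolates this change. Compound 1 also carries the entering group, though it differs elsewhere too, and it reaches 76% in this measurement. A rise beyond the scatter is therefore expected, with an estimated step of a number 34 percentage points higher from compound 2 to compound 3 (beyond the scatter) in this assay overall. The estimate for compound 3 is 52% with an expected range from 25% to 80% in this measurement.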

Compound 3, oral bioavailability: 44%
Compound 3: middle estimate off by 8 percentage points, on the high side, and the stated range covers the measured number.
By their numbers in this assay, from the lowest: compound 2; then compound 3; then compound 1.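

Changing the ring alone, with the aromatic ring replacing the non-aromatic one on the aromatic carbon, gives a number 26 percentage points higher from compound 2 to compound 3 (beyond the scatter) in this assay. Among the compounds shown here, the new compound also isolates the fluoro group for the first time: hydrogen in place of fluoro gives a number 32 percentage points lower from compound 1 to compound 3 (beyond the scatter). Each single change therefore moves the oral bioavailability beyond the scatter, so neither one is a silent swap on this core.

From the compounds shown here alone, whether a chloro group or a methoxy group could stand in for that fluoro stays open. Nothing measured here explains either step.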